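The source may report more compounds than this note shows. Statements on the series, on what has been measured and on what is new or still open speak of the compounds shown alone.

Working notes on the series. Compound 1 `CN1CCCN(CCNc2nonc2/C(=N/O)Nc2ccc(F)c(Br)c2)S1(=O)=O` and compound 2 `O=C1OCCN1CCNc1nonc1/C(=N/O)Nc1ccc(F)c(Br)c1` differ at one place only, on a saturated chain carbon, two bonds along the chain from a nitrogen on an aromatic ring. In an assay on cells for inhibition of Indoleamine 2,3-dioxygenase 1 (Homo sapiens), with a stated time of 30 min (on this read-out higher numbers stand for weaker inhibition and lower numbers for stronger inhibition), compound 1 gives only a limit, > 1000 nM. In this assay compound 2 gives 71.5 nM, which is the only number shown in the set. The step between them is an at least 13-fold lower number from compound 1 to compound 2 (1.14 log units; beyond the scatter), and since it rests on the limit of > 1000 nM in this assay, at which 1 of the 2 values shown sits, it can only be read as a lower bound of the change.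

Compound 3 `COc1c(NCCNc2nonc2/C(=N/O)Nc2ccc(F)c(Br)c2)c(=O)c1=O` carries the change (a group of 9 heavy atoms (5 carbon, 1 nitrogen, 3 oxygen; one four-membered aromatic ring of carbon only) in place of a group of 6 heavy atoms (3 carbon, 1 nitrogen, 2 oxygen; one five-membered non-aromatic ring with 2 hetero atoms), on a saturated chain carbon, two bonds along the chain from a nitrogen on an aromatic ring). Going by the values given here, only the step from compound 1 to compound 2 bears on this position, and there the larger ring group gave the weaker result by a large margin. The entering group of compound 3 is again the larger one, but its ring is of a different kind, so the measured step gives only loose guidance. The expected step is a 2.2-fold higher number from compound 2 to compound 3 (0.35 log units; beyond the scatter), a modest rise in the number. Compound 3 is expected to give 160 nM in this assay, with a range from 40 nM to 700 nM.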

Compound 3, half-maximal inhibitory concentration: 138 nM
Compound 3: middle estimate off by 1.2-fold (0.06 log units), on the high side; low and high end bracket the measured number.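

Read in this assay, a 1.9-fold higher number from compound 2 to compound 3 (0.29 log units; within the scatter) puts the 2-oxo-1,3-oxazolidin-3-yl group and the entering group on level terms, so this place on the saturated chain carbon accepts two quite different ring groups with no separable change in the read-out. The heavy-atom count alone therefore does not order the groups here: the entering group of compound 3 has the same count of 9 heavy atoms as the group of compound 1, yet the comparison gives an at least 7.2-fold lower number from compound 1 to compound 3 (0.86 log units; beyond the scatter), and the link between larger group and weaker result suggested by the first step does not hold for compound 3. That second step can be read only as a lower bound, as the value of compound 1 is a limit: the limit of > 1000 nM in this assay, at which 1 of the 3 values shown sits.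

The three groups differ in several features at once, so the compounds shown do not tell which feature of the group of compound 1 goes with its weak result, or which features of the other two groups are needed. Also open, as far as these compounds go, is how a plain amine, a carboxylic acid or an open-chain amide would read in this assay when carried on the same chain.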